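From 4-Methoxyphenyl to Furan-2-yl on the Amide Carbonyl

The compounds below may be only part of what the source reports. "The series", "measured", "known", "first", "only" and "open" are said of these compounds alone.

Two compounds have so far been tested in an assay on isolated protein for inhibition of aldehyde dehydrogenase 1A1 (Homo sapiens), read by spectrophotometry, tested at 10 uM; a lower number here means less inhibition, a higher number more inhibition at the concentration tested (going by the name of the read-out):

Compound 1, `Cc1cccc(Cn2c(CN3CCN(C(=O)CC(C)C)CC3)nc3ccccc32)c1`: 71.4%
Compound 2, `COc1ccc(C(=O)N2CCN(Cc3nc4ccccc4n3Cc3cccc(C)c3)CC2)cc1`: 55.5%

Going by the values given here, compound 2 stands lower of the two: the single measured step, a number 15.9 percentage points lower from compound 1 to compound 2 (beyond the scatter), lies beyond the scatter and puts compound 2 under compound 1. The next compound, compound 3, `Cc1cccc(Cn2c(CN3CCN(C(=O)c4ccco4)CC3)nc3ccccc32)c1`, differs from compound 2 in one place: furan-2-yl in place of 4-methoxyphenyl on a carbonyl carbon. Among the compounds with values here, only the step from compound 1 to compound 2 is available, and it exchanges a chain for a six-membered aromatic ring rather than one aromatic ring for another, so it bears on the present change only loosely. Within the data shown here, with no step that directly informs an aryl-to-heteroaryl exchange on the carbonyl, compound 3 is expected to stay near compound 2, with a step of a number 4.5 percentage points higher from compound 2 to compound 3 (within the scatter) that is estimated to fall within the scatter. Compound 3 is therefore estimated at 60%, with a range from 40% to 78%.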

Compound 3, a percentage reported as inhibition, at one concentration (the size of the read-out at that concentration, not a potency): 73.2%
Beside the measured number, compound 3's estimate is 13.2 percentage points below it; low and high end bracket the measured number.
By their numbers in this assay, from the lowest: compound 2; then compounds 1 and 3 (each within the scatter of the next).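

In this assay, the exchange on the carbonyl carbon proved far from neutral, with a number 17.7 percentage points higher from compound 2 to compound 3 (beyond the scatter) as furan-2-yl took the place of 4-methoxyphenyl. Going by these compounds alone, this shows that an aromatic ring on this carbonyl does not in itself go with the lower number, as the single earlier step might have suggested. Isobutyl and furan-2-yl cannot be told apart here, with a number 1.8 percentage points higher from compound 1 to compound 3 (within the scatter) on that exchange, so among these three compounds only compound 2, with its 4-methoxyphenyl, stands apart, and nothing available explains this difference.

As far as these compounds go, it remains open whether an unsubstituted phenyl or a thiophen-2-yl on the same carbonyl carbon would group with compound 2 or with compound 1 and compound 3. From the compounds shown here alone, all three compounds also share one core, so how far this reading extends to other cores is unknown.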